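Methylsulfonyl for carbamoyl at a solubility limit

The source may hold more compounds than are shown below. What is called first, only, known or untested is meant among the compounds shown, and "the series" means these compounds.

Of the compounds shown here, three built on a shared core have been measured so far. In a physicochemical assay for solubility, at pH 6.5 (on this read-out higher numbers stand for higher solubility and lower numbers for lower solubility), compound 1 `NC(=O)c1ccc(-c2cnc3ccc(-c4cccc(S(=O)(=O)C5CC5)c4)nn23)cc1` gives < 5000 nM, which is a limit and not a number. In this assay compound 2 `CS(=O)(=O)c1cccc(-c2ccc3ncc(-c4ccc(N)nc4)n3n2)c1` gives < 5000 nM, which is also a limit. In this assay compound 3 `C[S+]([O-])c1cccc(-c2ccc3ncc(-c4ccc(C(N)=O)cc4)n3n2)c1` gives < 5000 nM, again a limit. Compound 3 therefore has no exact place on the scale, and the whole set comes down to one entry: the limit of < 5000 nM in this assay, at which 3 of the 3 values shown sit.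

Compound 4 `C[S+]([O-])c1cccc(-c2ccc3ncc(-c4ccc(S(C)(=O)=O)cc4)n3n2)c1` differs from compound 3 in a single group: methylsulfonyl in place of carbamoyl on an aromatic carbon. It carries methylsulfonyl in place of carbamoyl on an aromatic carbon, para to a large group.

Going by the values given here, no measured step involves this exchange. The nearest is a change at a different group. A change beyond the usual scatter is not expected, and no direction can be given, because a step that the two limits leave unreadable from compound 1 to compound 3 offers nothing to carry over. The estimate amounts to a step that the limit leaves unreadable from compound 3 to compound 4, an expected step and not a measured one. For compound 4 the expected solubility is 3000 nM, within an estimated range of 1000 nM to 6000 nM, and another limit is the most likely report.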

Compound 4, solubility: 157000 nM
Compound 4: the middle estimate sits 52-fold (1.72 log units) below what was measured; the whole stated range lies below it.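

In this assay, this position, an aromatic carbon para to a large group, turns out to have a strong hold on the read-out: methylsulfonyl in place of carbamoyl gives an at least 31-fold higher number from compound 3 to compound 4 (1.49 log units; beyond the scatter). Going by these compounds alone, the earlier step between compound 1 and compound 3 cannot be read, which makes compound 4 the first compound here with a number instead of a limit, and the only one that later compounds can be compared with on the scale, while the others remain at a single entry: the limit of < 5000 nM in this assay, at which 3 of the 4 values shown sit. Carbamoyl carries 1 hydrogen-bond donor and methylsulfonyl 0 hydrogen-bond donors, but the two groups also differ in heavy atoms and hydrogen-bond acceptors, and one pair cannot show which of these differences matters.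

As far as these compounds go, this exchange rests on compound 3 and compound 4 alone, so it remains open whether it would give a similar step on a compound carrying the larger sulfur group of compound 1. From the compounds shown here alone, it also remains open how other groups at this position would compare, such as a nitrile, an amine or a carboxylic acid.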